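Amide aryl variation at the carbonyl carbon

This account rests on a few compounds, and the source may have more. Where it says the series, first, only, none or still open, it means among the compounds named here.

Compound 3 `O=C(Nc1cccc(Nc2ncc(F)c(Nc3ccc(F)cc3)n2)c1)c1ccncc1` carries pyridin-4-yl on the carbonyl carbon and, in a functional assay on KB cells (Homo sapiens) for antiproliferative activity, read by sulforhodamine B assay, with a stated time of 3 days (on this read-out higher numbers stand for weaker inhibition of growth and lower numbers for stronger inhibition of growth), compound 3 gives 5280 nM, the lowest of the two numbers available in the set. Compound 2 `O=C(Nc1cccc(Nc2ncc(F)c(Nc3ccc(F)cc3)n2)c1)c1cnccn1`, with pyrazin-2-yl in that place, gives 23600 nM, and the step of a 4.5-fold lower number from compound 2 to compound 3 (0.65 log units; beyond the scatter). Compound 1 `O=C(Nc1cccc(Nc2ncc(F)c(Nc3ccc(F)cc3)n2)c1)c1ccccc1`, with phenyl there, gives only a limit of the assay, > 10000 nM (the limit of > 10000 nM in this assay, at which 1 of the 3 values shown sits). Read against it, the step of an at least 1.8-fold lower number from compound 1 to compound 3 (0.27 log units; that floor lies within the scatter).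

Compound 4 `CN(C)c1ccc(C(=O)Nc2cccc(Nc3ncc(F)c(Nc4ccc(F)cc4)n3)c2)cc1` is not yet measured. Relative to compound 3 the change is 4-(dimethylamino)phenyl in place of pyridin-4-yl on a carbonyl carbon. Going by the values given here, the one measured step that bears on it is the phenyl-to-pyridin-4-yl step between compound 1 and compound 3, which ran toward a lower number but with a floor still inside the scatter; compound 4 moves back to a carbon-only ring, now with a dimethylamino substituent whose effect no measured pair covers. A step in the direction of a higher number is therefore expected, a 2.3-fold higher number from compound 3 to compound 4 (0.36 log units; beyond the scatter), with a real chance of a limit. Compound 4 is estimated at 12000 nM, within 3500 nM to 40000 nM.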

Compound 4, concentration for 50% growth inhibition: > 10000 nM
Compound 4 gave a limit, no number (the forecaster's own chance of this, stated with the estimate: 40%); the middle value does not contradict the limit.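

With compound 4, both carbon-only rings on the carbonyl carbon, phenyl and 4-(dimethylamino)phenyl, end at a limit of the assay, and among the compounds shown only pyridin-4-yl and pyrazin-2-yl return numbers. In this assay the new readable step is an at least 1.8-fold higher number from compound 3 to compound 4 (0.27 log units; that floor lies within the scatter), so the dimethylamino-bearing ring shows no gain over pyridin-4-yl, though no loss beyond the scatter is established either. The other steps to compound 4 cannot be read, and limits now cover much of this small set: the limit of > 10000 nM in this assay, at which 2 of the 4 values shown sit.

Still open, on these data alone, is whether pyridin-3-yl or pyridin-2-yl on the carbonyl carbon would give a lower number than compound 3 does. Also open, as far as these compounds go, is whether a morpholine or a carboxylic acid on the phenyl ring would bring that ring's compounds away from the limit.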